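Switching the aryl ketone: from nitro to trifluoromethyl

The source may hold more compounds than are shown below. What is called first, only, known or untested is meant among the compounds shown, and "the series" means these compounds.

Measured compounds:
- compound 1, `O=C(/C(=C\c1ccc([N+](=O)[O-])c(O)c1)SCc1ccc(Br)cc1)c1ccc(Br)cc1`, gives 10000 nM in a functional assay on DU-145 cells (Homo sapiens) for inhibition, read by trypan blue exclusion, with a stated time of 96 h; on this read-out lower numbers stand for stronger inhibition of growth and higher numbers for weaker inhibition of growth 
- compound 2, `O=C(/C(=C\c1ccc([N+](=O)[O-])c(O)c1)SCc1ccc(Br)cc1)c1cc(Cl)ccc1O`, gives 10000 nM in this assay
- compound 3, `O=C(/C(=C\c1ccc([N+](=O)[O-])c(O)c1)SCc1ccc(Br)cc1)c1ccc([N+](=O)[O-])c(Cl)c1`, gives 1000 nM in this assay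

Compound 3 has the lowest number of the three. The step of a 10-fold lower number from compound 1 to compound 3 (1.00 log units; beyond the scatter) and the step of a 10-fold lower number from compound 2 to compound 3 (1.00 log units; beyond the scatter) both go beyond the scatter, while the step of no change at the digits printed from compound 1 to compound 2 (within the scatter) stays within it, so compounds 1 and 2 cannot be ordered against each other.

Compound 4, `O=C(/C(=C\c1ccc([N+](=O)[O-])c(O)c1)SCc1ccc(Br)cc1)c1ccc(C(F)(F)F)cc1`, has not yet been measured. It differs from compound 3 as follows: 4-(trifluoromethyl)phenyl in place of 3-chloro-4-nitrophenyl on a carbonyl carbon. The step that bears on this change is a 10-fold lower number from compound 1 to compound 3 (1.00 log units; beyond the scatter), since the 4-bromophenyl of compound 1, like the entering 4-(trifluoromethyl)phenyl, carries a single group on one six-membered aromatic ring of carbon only and has 0 hydrogen-bond acceptors. Read backwards, that step suggests the number should rise again. Compound 4 is therefore expected to give 5000 nM, in a range of 1500 nM to 15000 nM, which is an estimated step of a 5.0-fold higher number from compound 3 to compound 4 (0.70 log units; beyond the scatter), toward but perhaps not fully back to the number of compound 1.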

Compound 4, concentration for 50% growth inhibition: 1000 nM
Estimate against measurement, compound 4: 5.0-fold (0.70 log units) above; the measured number lies below the stated range.
By their numbers in this assay, from the lowest: compounds 3 and 4 (each within the scatter of the next); then compounds 1 and 2 (each within the scatter of the next).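

In this assay, the 4-(trifluoromethyl)phenyl on the carbonyl carbon stands level with the 3-chloro-4-nitrophenyl (no change at the digits printed from compound 3 to compound 4 (within the scatter)), so among these compounds a nitro group is not needed to reach this number. The clearest new reading is the swap of trifluoromethyl in place of bromo on an aromatic carbon (a 10-fold lower number from compound 1 to compound 4 (1.00 log units; beyond the scatter)), which shows that this single group alone can move the number, and the change from the 5-chloro-2-hydroxyphenyl gives a step of the same size (a 10-fold lower number from compound 2 to compound 4 (1.00 log units; beyond the scatter)). No measured evidence is given that would explain these steps.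

The compounds shown leave open whether a phenyl on the carbonyl carbon bearing a nitrile, a methoxy group or a carboxylic acid would fall with compound 3 and compound 4 or with compound 1 and compound 2. They also leave open whether the swap from bromo to trifluoromethyl gives the same step on any other core.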